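Cyclobutyl to Propyl on a Brominated Benzotriazole Core

The compounds below may be only part of what the source reports. "The series", "measured", "known", "first", "only" and "open" are said of these compounds alone.

Three compounds have been run through an ADME assay on microsomes from liver (Rattus norvegicus, strain Wistar) for metabolic stability, tested at 2.5 uM; on this read-out higher numbers stand for fast clearance and lower numbers for slow clearance. Compound 1 `FC(F)(F)c1ccc(-c2ccc(Cn3nnc4ccccc43)cc2)c(Cl)c1` gives 0.5 mL/min/g in this assay. Compound 2 `Clc1ccc(Cn2nnc3c(Br)cccc32)cc1` gives 2.2 mL/min/g in this assay. Compound 3 `Brc1cccc2c1nnn2CC1CCC1` gives 12 mL/min/g in this assay, the highest of the three numbers: its gap to compound 2 is beyond the scatter, and its gap to compound 1 is also beyond the scatter, so compound 3 is the fastest-cleared of the three.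

The next compound, compound 4 `CCCCn1nnc2c(Br)cccc21`, keeps the brominated core of compound 3 and changes only the group attached to the aromatic nitrogen: propyl in place of cyclobutyl on a saturated chain carbon bound to an aromatic nitrogen. Within the data shown here, no pair of measured compounds shows this kind of change, so there is no measured step to lean on.

With compound 3 as the only anchor, the step from compound 3 to compound 4 in this assay is expected to be a 1.2-fold lower number from compound 3 to compound 4 (0.08 log units; within the scatter), that is, no change beyond the scatter. Compound 4 is therefore estimated to give 10 mL/min/g in this assay, with a likely range from 5 mL/min/g to 22 mL/min/g.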

Compound 4, intrinsic clearance in a liver preparation (reported as CLH), per the amount of preparation that the assay uses: 4.4 mL/min/g
Estimate against measurement, compound 4: 2.3-fold (0.36 log units) above; the whole stated range lies above it.
By their numbers in this assay, from the lowest: compound 1; then compounds 2 and 4 (each within the scatter of the next); then compound 3.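

In this assay, replacing cyclobutyl with propyl on a saturated chain carbon bound to an aromatic nitrogen gives a 2.7-fold lower number from compound 3 to compound 4 (0.44 log units; beyond the scatter). Among these compounds, this is the first measured step at this position, and it shows that the group here can move clearance beyond the scatter while the brominated core stays the same. Read one bond further out, the same difference is cyclobutylmethyl to butyl, so in this single pair the lower number goes with the open chain rather than the ring, and the data at hand offer no explanation for the step.

As far as these compounds go, whether a longer chain, a branched chain such as isopropyl, or a chain ending in an amine or a carboxylic acid would move the number further remains open. One pair also cannot tell whether the same swap would have a similar effect on a core without the bromine.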